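The compounds below may be only part of what the source reports. "The series", "measured", "known", "first", "only" and "open" are said of these compounds alone.

Measured in an ADME assay on the whole organism for pharmacokinetics, with Mus musculus as the target, at a dose of 10 mg/kg by the oral route; on this read-out higher numbers stand for higher exposure at the dose given and lower numbers for lower exposure:
compound 1 `CC/C(=C(/c1ccc(/C=C/C(=O)O)cc1)c1ccc2[nH]ncc2c1)c1ccccc1`: 5800 ng.h/mL
compound 2 `CC/C(=C(/c1ccc(/C=C/C(=O)O)cc1)c1ccc2[nH]ncc2c1)c1ccc(C#N)cc1Cl`: 2900 ng.h/mL

Going by the values given here, compound 2 lies within the scatter of the only other measured value. Compound 3 `CC/C(=C(/c1ccc(/C=C/C(=O)O)cc1)c1ccc2[nH]ncc2c1)c1ccncc1C` carries 3-methylpyridin-4-yl in place of 2-chloro-4-cyanophenyl on the same double-bonded chain carbon: 3-methylpyridin-4-yl in place of 2-chloro-4-cyanophenyl on a double-bonded chain carbon bound to a double-bonded chain carbon and a saturated chain carbon. Among the compounds with values here, one measured step bears on this place, a 2.0-fold lower number from compound 1 to compound 2 (0.30 log units; within the scatter). Within the data shown here, it is a single step and stays within the scatter, and no measured compound yet carries a ring with a hetero atom here. No change beyond the scatter is therefore expected, the expected step being a 1.2-fold higher number from compound 2 to compound 3 (0.08 log units; within the scatter). The estimate for compound 3 is 3500 ng.h/mL, with an expected range of 1300 ng.h/mL to 9000 ng.h/mL.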

Compound 3, area under the concentration-time curve: 81 ng.h/mL
Compound 3: middle estimate off by 43-fold (1.64 log units), on the high side; the measured number lies below the stated range.
By their numbers in this assay, from the lowest: compound 3; then compounds 2 and 1 (each within the scatter of the next).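

In this assay this position proves far less tolerant than the first two compounds suggested, with a large drop in both steps to the new ring (a 36-fold lower number from compound 2 to compound 3 (1.55 log units; beyond the scatter); a 72-fold lower number from compound 1 to compound 3 (1.85 log units; beyond the scatter)). 3-methylpyridin-4-yl thus separates from both carbon-only aromatic rings, whose own step stays within the scatter. Nothing measured here gives a reason for this loss of exposure.

Going by these compounds, whether the drop follows the ring nitrogen or the methyl remains open. Unsubstituted pyridin-4-yl and 3-methylphenyl at this place would separate the two.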